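Replacing a difluorophenyl by phenyl on a thiophene core

A few compounds are considered here, and "the series" means these few. Any claim that something is new, unique, unknown or untested is made for them only; others in the source may bear on it.

Compound 1, `CC(C)(C)Cc1c(-c2c(F)cccc2F)sc(N)c1C(=O)c1ccc(Cl)cc1`, was tested in an assay on CHO cells for displacement of a labelled ligand from adenosine receptor A3 (Homo sapiens), read by scintillation counting, tested at 10 uM (a higher number here means more inhibition at the concentration tested (going by the name of the read-out), a lower number less inhibition), where compound 1 gives 1%. Two related compounds, which differ from compound 1 in more than one place, were measured in the same way: compound 3, `CC(C)(C)Cc1csc(N)c1C(=O)c1cccc(C(F)(F)F)c1`, gives 1%, and compound 2, `CC(C)(C)Cc1csc(N)c1C(=O)c1ccc(Cl)c(Cl)c1`, gives 10%. Compound 1 and compound 3 are level at the digits shown, and together they sit at the bottom of the three numbers; compound 2 is higher by an amount that stays within the usual scatter of such measurements. In short, none of the three shows clear displacement of the labelled ligand at the concentration tested, and no difference among them can be trusted.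

The next compound, compound 4, `CC(C)(C)Cc1c(-c2ccccc2)sc(N)c1C(=O)c1ccc(Cl)cc1`, differs from compound 1 in a single place: phenyl in place of 2,6-difluorophenyl on an aromatic carbon. Among the measured compounds shown here, no measured pair in this set shows what such a change does on its own. Given that compound 1 gives 1% and that all three measured numbers stay within the scatter of one another, the step from compound 1 to compound 4 is expected to be a number 3 percentage points higher from compound 1 to compound 4 (within the scatter), with no change beyond the scatter in either direction. Compound 4 is therefore estimated at 4%, within a range from 0% to 15%.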

Compound 4, a percentage reported as inhibition, at one concentration (the size of the read-out at that concentration, not a potency): 1%
Compound 4: middle estimate off by 3 percentage points, on the high side; the measured number falls inside the stated range.
By their numbers in this assay, from the lowest: compounds 1, 3, 4 and 2 (each within the scatter of the next).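

Among the compounds shown here, this pair is the first in the set to isolate one change, and in this assay swapping 2,6-difluorophenyl for phenyl gives no change at the digits printed from compound 1 to compound 4 (within the scatter) with everything else in the molecule held constant. At this aromatic carbon next to the ring sulfur, then, the fluorines make no visible difference to the read-out, and the unsubstituted phenyl is no better or worse than its difluorinated counterpart at the concentration tested. The limit of this finding is that neither compound shows clear displacement of the labelled ligand, so the pair compares two flat results and says nothing about how the fluorines would behave in a compound that displaces it well. Nothing available here explains why the two compounds read alike.

Still open, on these data alone, is whether any group at this carbon can raise the read-out, for instance an amine, a carboxylic acid or a longer chain in place of the phenyl. Also open, as far as these compounds go, is what hydrogen at this carbon would do when the (4-chlorophenyl)carbonyl group stays unchanged.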